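Methyl to Vinyl on a Sulfonamide Oxazole Series

This account rests on a few compounds, and the source may have more. Where it says the series, first, only, none or still open, it means among the compounds named here.

Measured so far in an assay on cells for inhibition of HSP60/HSP10 (Homo sapiens), with a stated time of 60 min; a lower number here means a stronger inhibitor, a higher number a weaker inhibitor:
compound 1 `Cc1ccc(S(=O)(=O)Nc2ccc(-c3nc4ccccc4o3)cc2)cc1`: > 100000 nM
compound 2 `O=S(=O)(Nc1ccc2oc(-c3ccccc3)nc2c1)c1ccc(Cl)c(C(F)(F)F)c1`: > 100000 nM
compound 3 `O=S(=O)(Nc1ccc2oc(-c3ccccc3)nc2c1)c1cccs1`: 90000 nM

Compound 1 gives no number in this assay, only a limit, > 100000 nM. The same holds for compound 2, whose value > 100000 nM is also a limit. For the measured compounds named here, compound 3 is the one compound with a measured number, 90000 nM. Where compound 1 stands is therefore set by the limit of > 100000 nM in this assay, at which 2 of the 3 values shown sit; nothing on the number line separates it from its neighbours.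

Compound 4 `C=Cc1ccc(S(=O)(=O)Nc2ccc(-c3nc4ccccc4o3)cc2)cc1` has not yet been measured. It differs from compound 1 in one place only: vinyl in place of methyl on an aromatic carbon. Going by the values given here, no step between measured compounds involves this change, so there is no measured pair to lean on. Given that compound 1 sits at a limit in this assay, the expectation for compound 4 is no step beyond the scatter, neither stronger nor weaker.

Compound 4 is accordingly expected to give about 150000 nM, somewhere between 50000 nM and 500000 nM. The step this estimate means, a step that the limit leaves unreadable from compound 1 to compound 4, is expected to stay within the scatter, and the assay may well report only a limit again.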

Compound 4, half-maximal inhibitory concentration: > 100000 nM
Compound 4 ended at the assay's limit; the forecaster's own chance of this, stated with the estimate: 80%; the middle value is on the limit's open side.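

For the compounds shown here, compound 1 and compound 4 both sit at a limit and not at a number, and no step between them can be read. The series as shown mostly rests at that same point: the limit of > 100000 nM in this assay, at which 3 of the 4 values shown sit.

As far as these compounds go, whether vinyl in place of methyl on this core changes the result in this assay at all remains open.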